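Working notes: pyridyl isomer swap on the piperidine-like ring carbon

A few compounds are considered here, and "the series" means these few. Any claim that something is new, unique, unknown or untested is made for them only; others in the source may bear on it.

Measured so far:
Compound 1 `C[C@@H](NC1CCN(CCCc2c[nH]c3ccc(-n4cnnc4)cc23)CC1)c1ccccc1` gives 0.4 nM in an assay on CHO cells for displacement of a labelled ligand from 5-hydroxytryptamine receptor 1D (Homo sapiens); a lower number here means a stronger inhibitor, a higher number a weaker inhibitor.
Compound 2 `c1ccc(NCC2CCN(CCCc3c[nH]c4ccc(-n5cnnc5)cc34)CC2)nc1` gives 1.7 nM in this assay.

Within the data shown here, compound 2 holds the higher of the two numbers; the only measured step is a 4.3-fold higher number from compound 1 to compound 2 (0.63 log units; beyond the scatter), a modest loss that lies just beyond the scatter.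

Compound 3 `c1cncc(CNC2CCN(CCCc3c[nH]c4ccc(-n5cnnc5)cc34)CC2)c1` is not yet measured. Relative to compound 2 the change is ((pyridin-3-yl)methyl)amino in place of ((pyridin-2-yl)amino)methyl on a saturated ring carbon; the two are the same atoms joined differently, at the same ring carbon that the measured step altered. That step is the only one bearing on the question, and it compared groups of different composition, so it gives little guide to a rearrangement of one and the same group. With nothing in the data pointing either way, the step to compound 3 is expected to fall within the scatter or close to it, a 1.1-fold lower number from compound 2 to compound 3 (0.05 log units; within the scatter). Compound 3 is therefore estimated at 1.5 nM in this assay, with a range from 0.5 nM to 5 nM.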

Compound 3, half-maximal inhibitory concentration: 35 nM
Compound 3: middle estimate off by 23-fold (1.37 log units), on the low side; measured number above the stated range.
By their numbers in this assay, from the lowest: compound 1; then compound 2; then compound 3.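

Same atoms joined differently do not read alike at this saturated ring carbon: in this assay, ((pyridin-3-yl)methyl)amino in place of ((pyridin-2-yl)amino)methyl gives a 21-fold higher number from compound 2 to compound 3 (1.31 log units; beyond the scatter), so matching composition and matching counts of donors and acceptors do not keep the number here. With the amine nitrogen left on the ring carbon, (pyridin-3-yl)methyl in place of 1-phenylethyl on that nitrogen gives an 88-fold higher number from compound 1 to compound 3 (1.94 log units; beyond the scatter), so the group carried by that nitrogen also matters strongly. No measurement at hand accounts for either step.

From the compounds shown here alone, the step from compound 2 to compound 3 moves the amine nitrogen and the pyridine attachment together, so the share of each stays open. A plain benzyl group or a (pyridin-2-yl)methyl group on the same amine nitrogen would help separate the contribution of the pyridine nitrogen from that of the 1-phenylethyl branch.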